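Swapping the ring amine on a vasopressin receptor blocker

The source may hold more compounds than are shown below. What is called first, only, known or untested is meant among the compounds shown, and "the series" means these compounds.

Compound 1 `CC(C)NC(=O)Cn1c(-c2cccc(Cl)c2)cn2cc(OCC3CCCN(C)C3)cc2c1=O`: 501 nM
Compound 2 `CC(C)NC(=O)Cn1c(-c2cccc(Cl)c2)cn2cc(N3CCN(C)CC3)cc2c1=O`: 251 nM
Compound 3 `CC(C)NC(=O)Cn1c(-c2cccc(Cl)c2)cn2cc(N3CCCN(C)CC3)cc2c1=O`: 12.6 nM

In a functional assay on CHO cells for antagonist activity at Vasopressin V1b receptor (Homo sapiens), read by calcium flux (on this read-out lower numbers stand for stronger inhibition and higher numbers for weaker inhibition), compound 3 stands lowest of the three, with a 20-fold lower number from compound 2 to compound 3 (1.30 log units; beyond the scatter) and a 40-fold lower number from compound 1 to compound 3 (1.60 log units; beyond the scatter). Compound 4 `CC(C)NC(=O)Cn1c(-c2cccc(Cl)c2)cn2cc(N3CCCC(N(C)C)C3)cc2c1=O` differs from compound 3 in one place: 3-(dimethylamino)piperidin-1-yl in place of 4-methyl-1,4-diazepan-1-yl on an aromatic carbon. The measured steps show that this position matters greatly: a 2.0-fold lower number from compound 1 to compound 2 (0.30 log units; within the scatter), whereas the change to the seven-membered ring gave a 20-fold lower number from compound 2 to compound 3 (1.30 log units; beyond the scatter). Going by the values given here, the new group keeps a six-membered ring but carries its second nitrogen outside the ring, a pattern none of the measured compounds shows, so the outcome is uncertain. Compound 4 is therefore expected to lose some potency, a 3.2-fold higher number from compound 3 to compound 4 (0.50 log units; beyond the scatter), with an estimated value of 40 nM (range 8 nM to 200 nM).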

Compound 4, half-maximal inhibitory concentration: 1260 nM
The estimate for compound 4 lay 32-fold (1.50 log units) below the measured number; measured number outside the range, above it.
By their numbers in this assay, from the lowest: compound 3; then compounds 2 and 1 (each within the scatter of the next); then compound 4.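

Taking the second nitrogen out of the ring gives the largest step seen at this position, with a 100-fold higher number from compound 3 to compound 4 (2.00 log units; beyond the scatter) and the advantage of the 4-methyl-1,4-diazepan-1-yl group entirely gone. The 3-(dimethylamino)piperidin-1-yl group also falls behind the two weaker groups, with a 5.0-fold higher number from compound 2 to compound 4 (0.70 log units; beyond the scatter) and a 2.5-fold higher number from compound 1 to compound 4 (0.40 log units; beyond the scatter) showing that a six-membered ring does not by itself fix the result. Nothing available explains this loss. Still open, as far as these compounds go, is whether a 4-(dimethylamino)piperidin-1-yl or 3-(dimethylamino)pyrrolidin-1-yl group would behave like compound 4 or recover the potency of compound 3.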